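Cytotoxicity notes: benzylsulfanyl variation in the series

The compounds below may be only part of what the source reports. "The series", "measured", "known", "first", "only" and "open" are said of these compounds alone.

Measured in an ADME assay on HaCaT cells (Homo sapiens) for cytotoxicity, read by MTT assay, with a stated time of 72 h; a higher number here means a weaker inhibitor, a lower number a stronger inhibitor:
compound 1 `Cc1cccc(CSc2cc(Cl)c(C)cc2S(=O)(=O)/N=C(\N)n2nccc2-c2ccccc2)c1`: 10000 nM
compound 2 `Cc1ccc(CSc2cc(Cl)c(C)cc2S(=O)(=O)/N=C(\N)n2nc(C)cc2-c2ccccc2)cc1`: 30000 nM
compound 3 `Cc1cc(-c2ccccc2)n(/C(N)=N/S(=O)(=O)c2cc(C)c(Cl)cc2SCc2ccc(Cl)cc2)n1`: 11000 nM

In this assay compound 1 sits at the low end of the three numbers, within the scatter of compound 3 and separated beyond the scatter from compound 2. Compound 4 `Cc1cc(S(=O)(=O)/N=C(\N)n2nccc2-c2ccccc2)c(SCc2ccccc2C(F)(F)F)cc1Cl` differs from compound 1 by 2-(trifluoromethyl)phenyl in place of 3-methylphenyl on a saturated chain carbon bound to a sulfur. Among the measured compounds shown here, the only measured step, a 2.7-fold lower number from compound 2 to compound 3 (0.44 log units; beyond the scatter), concerns chloro in place of methyl on an aromatic carbon and not the benzylsulfanyl group, so it bears only loosely on this change; no measured step addresses 2-(trifluoromethyl)phenyl. No shift beyond the scatter is therefore expected, and the estimated step of a 1.3-fold lower number from compound 1 to compound 4 (0.10 log units; within the scatter) is kept small. Compound 4 is expected to give 8000 nM in this assay, between 3000 nM and 25000 nM.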

Compound 4, half-maximal inhibitory concentration: 20000 nM
Beside the measured number, compound 4's estimate is 2.5-fold (0.40 log units) below it; the range from low to high includes it.
By their numbers in this assay, from the lowest: compounds 1, 3, 4 and 2 (each within the scatter of the next, the first and the last beyond it).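

In this assay the change from 3-methylphenyl to 2-(trifluoromethyl)phenyl on a saturated chain carbon bound to a sulfur gives a 2.0-fold higher number from compound 1 to compound 4 (0.30 log units; within the scatter) and stays within the scatter. Among the compounds shown here, this is the first step that reads this position directly, and the larger aryl group leaves the number without a shift beyond the scatter. No supporting measurement bears on this result, so it carries no explanation.

Because the step alters both the substituent and its location on the ring, the two contributions cannot be separated. Open too, from the compounds shown here alone, is whether an amine or a carboxylic acid at this carbon would move the number beyond the scatter.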